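The source may report more compounds than this note shows. Statements on the series, on what has been measured and on what is new or still open speak of the compounds shown alone.

Antiproliferative work on this series begins with compound 2 (`CN(C)CC(=O)Nc1n[nH]c2c1CN(C(=O)C(C)(C)C)C2(C)C`), which gives 580 nM in a functional assay on A2780 cells (Homo sapiens) for antiproliferative activity, read by fluorescence, with a stated time of 72 h; a higher number here means a weaker inhibitor, a lower number a stronger inhibitor. Compound 1 (`CC(C)(C)C(=O)N1Cc2c(NC(=O)C3CCNCC3)n[nH]c2C1(C)C`) gives 650 nM, level with compound 2 within the scatter. Compound 3 (`CN1CCC(C(=O)N2Cc3c(NC(=O)c4ccc(F)c(F)c4)n[nH]c3C2(C)C)CC1`) gives 100 nM, a clearly lower number than the other two and so the strongest inhibitor of the three.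

The next compound is compound 4 (`CC(C)(C)C(=O)N1Cc2c(NC(=O)c3ccncc3)n[nH]c2C1(C)C`), which has pyridin-4-yl in place of (dimethylamino)methyl on a carbonyl carbon.

Among the compounds with values here, only one measured step changes a group at this carbonyl carbon. It puts (dimethylamino)methyl in place of piperidin-4-yl and amounts to a 1.1-fold lower number from compound 1 to compound 2 (0.05 log units; within the scatter). That swap shows that one change at this place left the number unmoved, but neither group in it is aromatic, so it says little about pyridin-4-yl. Compound 3, at 100 nM, does carry an aromatic ring on the matching carbonyl carbon, but it also differs from compound 2 elsewhere, so it offers only a weak hint towards a lower number.

In this assay, a modest move towards stronger inhibition is therefore expected. The expected step is a 2.3-fold lower number from compound 2 to compound 4 (0.37 log units; beyond the scatter). For compound 4 the estimated value is 250 nM, with an expected range of 80 nM to 750 nM.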

Compound 4, half-maximal inhibitory concentration: 110 nM
Compound 4: the middle estimate sits 2.3-fold (0.36 log units) above what was measured; the range from low to high includes it.
By their numbers in this assay, from the lowest: compounds 3 and 4 (each within the scatter of the next); then compounds 2 and 1 (each within the scatter of the next).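

At this carbonyl carbon, exchanging piperidin-4-yl for (dimethylamino)methyl left the number within the scatter, but pyridin-4-yl brings a real change in this assay: a 5.3-fold lower number from compound 2 to compound 4 (0.72 log units; beyond the scatter), and a 5.9-fold lower number from compound 1 to compound 4 (0.77 log units; beyond the scatter). The position is therefore not indifferent to the group it carries, and in both one-place comparisons the step beyond the scatter comes with an aromatic ring replacing a non-aromatic group, a pattern that rests on these three compounds alone. Nothing measured here explains why the number falls.

The compounds shown leave open whether the aromatic ring alone accounts for the step or whether its nitrogen also plays a part, a question that an unsubstituted phenyl group on the same carbonyl carbon, compared with compound 4 in a one-place step, could help to answer. On these data alone, they also leave open how a carboxylic acid or a longer chain ending in an amine would behave at this position, so the range of groups tolerated here remains unknown.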